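Ester side chains and cytotoxicity in a small series

The compounds below may be only part of what the source reports. "The series", "measured", "known", "first", "only" and "open" are said of these compounds alone.

Measured in a functional assay on HeLa cells (Homo sapiens) for cytotoxicity, read by MTT assay; on this read-out lower numbers stand for stronger inhibition and higher numbers for weaker inhibition:
- compound 1 `COCCO[C@H](CC=C(C)C)C1=CC(=O)c2c(O)ccc(O)c2C1=O`: 62400 nM
- compound 2 `CC(C)=CC[C@@H](OC(=O)CC(C)(O)C(C)C)C1=CC(=O)c2c(O)ccc(O)c2C1=O`: 27700 nM
- compound 3 `CC(C)=CC[C@@H](OC(=O)C1CCCO1)C1=CC(=O)c2c(O)ccc(O)c2C1=O`: 17000 nM

Compound 2 and compound 3 lie within the scatter of each other, and both lie lower than compound 1: a 2.3-fold lower number from compound 1 to compound 2 (0.35 log units; beyond the scatter) and a 3.7-fold lower number from compound 1 to compound 3 (0.56 log units; beyond the scatter).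

Compound 4 `CCCC(C)(O)CC(=O)O[C@H](CC=C(C)C)C1=CC(=O)c2c(O)ccc(O)c2C1=O` differs from compound 3 as follows: 2-hydroxy-2-methylpentyl in place of oxolan-2-yl on a carbonyl carbon. The closest measured change is a 1.6-fold lower number from compound 2 to compound 3 (0.21 log units; within the scatter), which puts oxolan-2-yl in place of 2-hydroxy-2,3-dimethylbutyl on a carbonyl carbon and stays within the scatter. The expected step is a 1.4-fold higher number from compound 3 to compound 4 (0.15 log units; within the scatter), toward a higher number but not beyond the scatter in this assay. Compound 4 is estimated at 24000 nM, with an expected range of 10000 nM to 55000 nM.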

Compound 4, half-maximal inhibitory concentration: 72000 nM
Compound 4: the middle estimate sits 3.0-fold (0.48 log units) below what was measured; the measured number lies above the stated range.
By their numbers in this assay, from the lowest: compounds 3 and 2 (each within the scatter of the next); then compounds 1 and 4 (each within the scatter of the next).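

In this assay this ester position responds to the acyl chain itself, with a 4.2-fold higher number from compound 3 to compound 4 (0.63 log units; beyond the scatter) when 2-hydroxy-2-methylpentyl replaces oxolan-2-yl on the carbonyl carbon. Even two open chains carrying a hydroxyl separate here, with a 2.6-fold higher number from compound 2 to compound 4 (0.41 log units; beyond the scatter) for propyl in place of isopropyl, a difference not probed by the earlier compounds. An ester alone therefore does not set the number, since a 1.2-fold higher number from compound 1 to compound 4 (0.06 log units; within the scatter) leaves this ester and the 2-methoxyethyl group unseparated. Nothing available accounts for these steps. As far as these compounds go, how an amine or a carboxylic acid on the acyl chain would read out remains open.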